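This account rests on a few compounds, and the source may have more. Where it says the series, first, only, none or still open, it means among the compounds named here.

Measured so far in an in vitro functional assay on RBL cells for antagonist activity at C-C chemokine receptor type 8 (Homo sapiens), read by FLIPR and calcium flux; a higher number here means a weaker inhibitor, a lower number a stronger inhibitor:
compound 1 `COc1ccc2nccc(C3CN(C4CCN(Cc5cc6ccccc6s5)CC4)C(=O)O3)c2c1` gives 794 nM
compound 2 `COc1ccc2nccc(C3CN(C4CCN(Cc5ccc6ccccc6c5)CC4)C(=O)O3)c2c1` gives 1260 nM
compound 3 `COc1ccc2nccc(C3CN(C4CCN(CCCc5ccccc5)CC4)C(=O)O3)c2c1` gives 251 nM

Compound 3 stands lowest of the three numbers in this assay; its nearest neighbour is compound 1 and its furthest is compound 2, both steps beyond the scatter. Of the measured steps, compound 1 to compound 2 reads a 1.6-fold higher number from compound 1 to compound 2 (0.20 log units; within the scatter), whereas a 3.2-fold lower number from compound 1 to compound 3 (0.50 log units; beyond the scatter) and a 5.0-fold lower number from compound 2 to compound 3 (0.70 log units; beyond the scatter).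

Compound 4 `COc1ccc(CN2CCC(N3CC(c4ccnc5ccc(OC)cc45)OC3=O)CC2)cc1` differs from compound 3 by 4-methoxyphenyl in place of phenethyl on a saturated chain carbon bound to an amine nitrogen in a ring. Among the measured compounds shown here, no measured pair covers this exact exchange. What the series does show is that the two compounds carrying an aromatic group directly on that carbon, compound 1 and compound 2, both sit higher than compound 3, and compound 4 returns an aromatic group to that position, though a single ring bearing a methoxy rather than 1-benzothiophen-2-yl or naphthalen-2-yl. The expectation is therefore a modest rise in the number, of a size short of the steps from compound 1 and compound 2, and with wide uncertainty given the absence of a direct precedent. Compound 4 is estimated at 500 nM in this assay, with a range of 160 nM to 1600 nM, which means an expected step of a 2.0-fold higher number from compound 3 to compound 4 (0.30 log units; within the scatter).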

Compound 4, half-maximal inhibitory concentration: 1260 nM
The estimate for compound 4 lay 2.5-fold (0.40 log units) below the measured number, within the range that was stated.
By their numbers in this assay, from the lowest: compound 3; then compounds 1, 2 and 4 (each within the scatter of the next).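

In this assay, the 4-methoxyphenyl exchange gives a 5.0-fold higher number from compound 3 to compound 4 (0.70 log units; beyond the scatter) and so places a single-ring group on the saturated chain carbon bound to an amine nitrogen in a ring at the level of the two larger aromatic groups, with no change at the digits printed from compound 2 to compound 4 (within the scatter) and a 1.6-fold higher number from compound 1 to compound 4 (0.20 log units; within the scatter) as the steps from naphthalen-2-yl and 1-benzothiophen-2-yl. Among compounds 1, 2 and 4, the choice of aromatic group at this carbon therefore does not separate the numbers, and only compound 3, with its 3-phenylpropyl group in place of the 4-methoxybenzyl group of compound 4, stands apart beyond the scatter. No supporting data bear on why this step occurs.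

Because the change from 3-phenylpropyl to 4-methoxybenzyl alters both the chain and the ring substituent, the compounds shown cannot assign the step to either one. An unsubstituted benzyl group and a 3-(4-methoxyphenyl)propyl group would separate the two, and a longer chain would show whether the trend with chain length continues past 3-phenylpropyl.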